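Ester-bearing enoate replaces the hydroxybutenyl chain on compound 2

This account rests on a few compounds, and the source may have more. Where it says the series, first, only, none or still open, it means among the compounds named here.

Compound 1, `CC(C)(C)[Si](C)(C)O[C@H]1CCCO[C@@H]1CCO`: 55000 nM
Compound 2, `CC(C)(C)[Si](C)(C)O[C@H]1CCCO[C@@H]1C/C=C/CO`: 25000 nM

Of the compounds shown here, two sharing the same core have been measured in a functional assay on MCF7S cells (Homo sapiens); a higher number here means a weaker inhibitor of growth, a lower number a stronger inhibitor of growth. Compound 1 gives 55000 nM in this assay, and compound 2 gives 25000 nM. For the measured compounds named here, the one step between them, a 2.2-fold lower number from compound 1 to compound 2 (0.34 log units; beyond the scatter), followed the exchange of a hydroxymethyl for a 3-hydroxyprop-1-en-1-yl on a saturated chain carbon bound to a saturated ring carbon. Going by the values given here, on these two numbers compound 2 stands lowest, with compound 1 as its only neighbour.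

Compound 3, `COC(=O)/C=C/[C@H]1OCCC[C@@H]1O[Si](C)(C)C(C)(C)C`, is the next compound on this path. It differs from compound 2 in one place: 2-(methoxycarbonyl)ethenyl in place of 4-hydroxybut-2-en-1-yl on a saturated ring carbon. The measured step bears on this change only loosely, since it kept the hydroxyl at the chain end and merely lengthened the chain, whereas here the chain loses its hydroxyl and gains an ester. Among the compounds with values here, with no measured precedent for such a change, the expectation rests on compound 2 alone: compound 3 is expected to stay near compound 2, giving an estimated step of a 1.3-fold lower number from compound 2 to compound 3 (0.10 log units; within the scatter) in this assay. The estimated value for compound 3 is therefore 20000 nM, with a wide range from 5000 nM to 80000 nM.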

Compound 3, concentration for 50% growth inhibition: 24000 nM
For compound 3 the middle estimate is 1.2-fold (0.08 log units) below the measured one, and the stated range covers the measured number.
By their numbers in this assay, from the lowest: compounds 3 and 2 (each within the scatter of the next); then compound 1.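

In this assay, placing 2-(methoxycarbonyl)ethenyl instead of 4-hydroxybut-2-en-1-yl on this saturated ring carbon next to the ring oxygen gives a step within the scatter (a 1.0-fold lower number from compound 2 to compound 3 (0.02 log units; within the scatter)), so the chain-end hydroxyl of compound 2 is not needed to keep the number seen for that compound, and an ester-bearing chain with no hydrogen-bond donor serves equally well in this pair. Set against the 2-hydroxyethyl chain, the same group gives a modest step beyond the scatter (a 2.3-fold lower number from compound 1 to compound 3 (0.36 log units; beyond the scatter)), which shows that a chain without a hydroxyl can match the step seen with the hydroxyl-bearing 4-hydroxybut-2-en-1-yl chain. No other measurement accompanies these numbers, and nothing available accounts for them.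

On these data alone, whether a carboxylic acid in place of the methyl ester, or a longer chain carrying the ester, would shift the number remains open, as does the share of the double bond in the step from the 2-hydroxyethyl chain. As far as these compounds go, all three compounds also keep the tert-butyldimethylsilyl ether, so what a free hydroxyl on that ring carbon would do remains unknown.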